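This account rests on a few compounds, and the source may have more. Where it says the series, first, only, none or still open, it means among the compounds named here.

Compound 3 `COc1cccc(OC)c1OCCNCCOc1ccccc1OCc1ccc([N+](=O)[O-])cc1` shows the lowest of the three numbers measured in an assay on CHO cells for displacement of a labelled ligand from Alpha-1B adrenergic receptor (Homo sapiens) (on this read-out lower numbers stand for stronger inhibition and higher numbers for weaker inhibition), where compound 3 gives 0.398 nM, although all three lie within the scatter of one another. Its nearest neighbour is compound 1 `COc1cccc(OC)c1OCCNCCOc1ccccc1OCc1ccccc1`, which in this assay gives 0.537 nM; the furthest is compound 2 `COc1cccc(OC)c1OCCNCCOc1ccccc1OCc1cccc([N+](=O)[O-])c1`, for which this assay gives 0.794 nM. Compound 4 `COc1ccc(COc2ccccc2OCCNCCOc2c(OC)cccc2OC)cc1` differs from compound 3 in one place: methoxy in place of nitro on an aromatic carbon. For the measured compounds named here, the steps that bear on this change are a 1.3-fold lower number from compound 1 to compound 3 (0.13 log units; within the scatter), a 1.5-fold higher number from compound 1 to compound 2 (0.17 log units; within the scatter) and a 2.0-fold lower number from compound 2 to compound 3 (0.30 log units; within the scatter), each within the scatter. A change on this ring is therefore expected to move the number no further than the scatter, and compound 4 is estimated to read 0.5 nM, between 0.25 nM and 1 nM, which is expected to be a 1.3-fold higher number from compound 3 to compound 4 (0.10 log units; within the scatter).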

Compound 4, inhibition constant: 0.398 nM
Beside the measured number, compound 4's estimate is 1.3-fold (0.10 log units) above it, and the stated range covers the measured number.
By their numbers in this assay, from the lowest: compounds 3, 4, 1 and 2 (each within the scatter of the next).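

In this assay, methoxy in place of nitro on this aromatic carbon, para to a large group, shows no change at the digits printed from compound 3 to compound 4 (within the scatter), so the position now holds a group other than nitro without a step beyond the scatter. For the compounds shown here, the methoxy compound gives the same picture against the earlier compounds, with a 1.3-fold lower number from compound 1 to compound 4 (0.13 log units; within the scatter) and a 2.0-fold lower number from compound 2 to compound 4 (0.30 log units; within the scatter). Nothing available explains why these exchanges leave the number within the scatter. From the compounds shown here alone, whether an amine or a carboxylic acid at this position would also stay within the scatter remains open.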